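The source may hold more compounds than are shown below. What is called first, only, known or untested is meant among the compounds shown, and "the series" means these compounds.

The measured compounds are these. Compound 1, `COc1ccn2c(-c3ccc(NC(=O)c4ccc([N+](=O)[O-])o4)cc3C)cnc2c1`, gives 640 nM in a functional assay on AGS cells (Homo sapiens) for antiproliferative activity, read by CCK-8 assay, with a stated time of 72 h; a lower number here means a stronger inhibitor, a higher number a weaker inhibitor. Compound 3, `COc1ccn2c(-c3ccc(NC(=O)c4ccc([N+](=O)[O-])o4)c(C)c3)cnc2c1`, gives 430 nM in this assay. Compound 2, `COc1ccn2c(-c3ccc(NC(=O)c4ccc([N+](=O)[O-])o4)cc3OC)cnc2c1`, gives > 20000 nM, which is a limit of the assay and not a number.

Compound 1 and compound 3 are built from the same atoms joined differently; the difference between the two cores is not broken down here. Their two values lie within the usual scatter of each other. Compound 2 sits at the limit of > 20000 nM in this assay, at which 1 of the 3 values shown sits. The step from compound 1 to compound 2 is an at least 31-fold higher number from compound 1 to compound 2 (1.49 log units; beyond the scatter), made by methoxy in place of methyl on an aromatic carbon.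

Compound 4, `COc1ccn2c(-c3ccc(NC(=O)c4ccc([N+](=O)[O-])o4)c(OC)c3)cnc2c1`, has not yet been measured in this assay. It differs from compound 3 by methoxy in place of methyl on an aromatic carbon, the same change, at the same kind of place, as that between compound 1 and compound 2. A step of a 28-fold higher number from compound 3 to compound 4 (1.45 log units; beyond the scatter) is therefore expected for compound 4, resting on the step of an at least 31-fold higher number from compound 1 to compound 2 (1.49 log units; beyond the scatter). For compound 4 the expected value is 12000 nM, estimated between 2000 nM and 20000 nM.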

Compound 4, half-maximal inhibitory concentration: 3880 nM
For compound 4 the middle estimate is 3.1-fold (0.49 log units) above the measured one; measured number inside the range.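

In this assay methoxy in place of methyl again gives a weaker compound on the second core, with a 9.0-fold higher number from compound 3 to compound 4 (0.96 log units; beyond the scatter) as the step, so the direction of the change holds in both pairs. The direction carried across, but the size of the step did not: the same change on two cores in this assay, an at least 31-fold higher number (1.49 log units; beyond the scatter) from compound 1 to compound 2 and a 9.0-fold higher number (0.96 log units; beyond the scatter) from compound 3 to compound 4, at least 3.4-fold (0.53 log units) apart, beyond the scatter of two such steps. As far as these compounds go, compound 2 gives > 20000 nM and this is a limit of the assay and not a number, so the true size of the earlier step stays unknown, and the gap between the two steps could be wider still.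

Two pairs cannot show whether the direction would hold on a further core, nor why the two cores differ in how much they respond. The compounds shown also leave open how other groups would behave in place of methyl, such as an ethyl group, a chlorine atom or an amine.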